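The compounds below may be only part of what the source reports. "The series", "measured", "known", "first", "only" and "open" are said of these compounds alone.

Compounds 1, 2 and 3 share one core and differ only in the group on a carbonyl carbon: compound 1 `CC(C)C[C@H](N)C(=O)NS(=O)(=O)OC[C@H]1O[C@@H](n2cnc3c(N)ncnc32)[C@H](O)[C@@H]1O`, compound 2 `CC[C@H](C)[C@H](N)C(=O)NS(=O)(=O)OC[C@H]1O[C@@H](n2cnc3c(N)ncnc32)[C@H](O)[C@@H]1O` and compound 3 `Nc1ncnc2c1ncn2[C@@H]1O[C@H](COS(=O)(=O)NC(=O)[C@@H]2CCN2)[C@@H](O)[C@H]1O`. In a functional assay on PBMC cells (Homo sapiens) for inhibition (on this read-out higher numbers stand for weaker inhibition and lower numbers for stronger inhibition), compound 1 gives 1100 nM, compound 2 gives 5600 nM and compound 3 gives 600 nM. Compound 3 has the lowest of the three numbers; its gap to compound 1 is within the scatter, whereas a 9.3-fold lower number from compound 2 to compound 3 (0.97 log units; beyond the scatter). Among the measured steps, a 5.1-fold higher number from compound 1 to compound 2 (0.71 log units; beyond the scatter), while a 1.8-fold lower number from compound 1 to compound 3 (0.26 log units; within the scatter). Compound 4 `Nc1ncnc2c1ncn2[C@@H]1O[C@H](COS(=O)(=O)NC(=O)[C@@H]2CSCN2)[C@@H](O)[C@H]1O` alters the ring itself: 1,3-thiazolidin-4-yl in place of azetidin-2-yl on a carbonyl carbon. Among the compounds with values here, no measured step exchanges one ring for another, so the earlier steps bear on this change only indirectly; both steps that touch the ring of compound 3 were at most modest. The step of a 1.5-fold higher number from compound 3 to compound 4 (0.18 log units; within the scatter) is expected to be small, within or only a little beyond the scatter, in the direction of a slightly higher number in this assay. For compound 4 the estimate in this assay is 900 nM, within a range from 300 nM to 3000 nM.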

Compound 4, half-maximal inhibitory concentration: 550 nM
The estimate for compound 4 lay 1.6-fold (0.21 log units) above the measured number, within the range that was stated.
By their numbers in this assay, from the lowest: compounds 4, 3 and 1 (each within the scatter of the next); then compound 2.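

In this assay, within the data shown here, exchanging one ring for another on the carbonyl carbon gave a 1.1-fold lower number from compound 3 to compound 4 (0.04 log units; within the scatter), so azetidin-2-yl and 1,3-thiazolidin-4-yl cannot be told apart here, a comparison of two rings that the earlier compounds did not offer. Set against the open-chain groups, 1,3-thiazolidin-4-yl gave a 2.0-fold lower number from compound 1 to compound 4 (0.30 log units; within the scatter) for 1-amino-3-methylbutyl, but a 10-fold lower number from compound 2 to compound 4 (1.01 log units; beyond the scatter) for 1-amino-2-methylbutyl, so the gap to the latter group, already seen with the azetidin-2-yl ring, is seen with this second ring too. No evidence at hand accounts for these results.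

The compounds shown leave open how a pyrrolidin-2-yl group, which has the five-membered ring without the sulfur atom, would read at this place. They also leave open whether a piperidin-2-yl group would fit the same picture.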